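A few compounds are considered here, and "the series" means these few. Any claim that something is new, unique, unknown or untested is made for them only; others in the source may bear on it.

Of the compounds shown here, three share one core and have been measured in a physicochemical assay for lipophilicity, read by HPLC; a lower number here means a more polar compound, a higher number a more lipophilic compound. Compound 1, `O=C(Nc1ccccc1C(F)(F)F)c1ccc2cccc(O)c2n1`, gives 2.5 in this assay. Compound 2, `O=C(Nc1ccc(C(F)(F)F)cc1)c1ccc2cccc(O)c2n1`, gives 2.5. Compound 3, `O=C(Nc1ccccc1[N+](=O)[O-])c1ccc2cccc(O)c2n1`, gives 2.5. Compounds 1 and 2 are built from the same atoms joined differently; the difference between the two cores is not broken down here, and the two values stand level with each other within the scatter. Compound 3 differs from compound 1 in one place, (nitro in place of trifluoromethyl on an aromatic carbon), and the step from compound 1 to compound 3 is no change at the digits printed from compound 1 to compound 3 (within the scatter), so the nitro group and the trifluoromethyl group give the same reading in this setting.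

Compound 4, `O=C(Nc1ccc([N+](=O)[O-])cc1)c1ccc2cccc(O)c2n1`, has not yet been measured. It differs from compound 2 by nitro in place of trifluoromethyl on an aromatic carbon. Within the data shown here, this is the same kind of change as the one from compound 1 to compound 3, but not the same: in compound 3 the nitro group stands ortho to a large group, in compound 4 it stands para to a large group. Because the earlier step was no change at the digits printed from compound 1 to compound 3 (within the scatter), the step from compound 2 to compound 4 is expected to be small as well, estimated as a number 0.10 log units lower from compound 2 to compound 4 (within the scatter). Compound 4 is therefore expected to give about 2.4 in this assay, with a likely range from 2 to 2.8. Among the measured compounds shown here, the one measured example is the only support for this expectation.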

Compound 4, partition coefficient: 2.5
Beside the measured number, compound 4's estimate is 0.10 log units below it; the range from low to high includes it.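

In this assay, among these compounds, the change of nitro in place of trifluoromethyl has now been read in two settings: the first step is no change at the digits printed from compound 1 to compound 3 (within the scatter), and the second, with the nitro group para to a large group, is no change at the digits printed from compound 2 to compound 4 (within the scatter), so in both pairs the change leaves the reading where it was when carried from the core of compound 1 to the core of compound 2. This does not show that the two groups read alike throughout the series, since two pairs in a single assay are all that stand behind it, and a real difference smaller than the scatter would not appear in either step. Nothing measured here says why the readings stay level, so the two steps record an outcome and give no explanation for it.

The compounds shown carry only trifluoromethyl and nitro on this ring, which leaves open what an amine or a carboxylic acid would read in the same place. Also open, on these data alone, is whether a longer chain, such as a butyl group, would move the reading beyond the scatter where these two groups do not.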